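Swapping Chloro for Methyl on a Channel Blocker

The source may hold more compounds than are shown below. What is called first, only, known or untested is meant among the compounds shown, and "the series" means these compounds.

Measured so far:
Compound 1, `CC(O)(C(=O)Nc1ccc(C(=O)c2ccccc2)cc1C#N)C(F)(F)F`: in a functional assay (Cavia porcellus) with sulfonylurea receptors; K-ATP channels (Homo sapiens) as the target (on this read-out higher numbers stand for weaker inhibition and lower numbers for stronger inhibition), compound 1 gives 3800 nM.
Compound 2, `CC(O)(C(=O)Nc1ccc(C(=O)c2ccccc2)cc1Cl)C(F)(F)F`: in this assay compound 2 reaches only a limit of the assay, > 30000 nM.

Compound 2 therefore stands at the weak end of the two numbers shown, and its value is a limit rather than a measured number. The step of an at least 7.8-fold higher number from compound 1 to compound 2 (0.89 log units; beyond the scatter) is known only as a lower bound (the limit of > 30000 nM in this assay, at which 1 of the 2 values shown sits).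

Compound 3, `Cc1cc(C(=O)c2ccccc2)ccc1NC(=O)C(C)(O)C(F)(F)F`, differs from compound 2 by methyl in place of chloro on an aromatic carbon. No measured step exchanges chloro for methyl; the only step shown exchanged cyano for chloro, which gives no direct guidance here. Compound 3 is expected to stay near compound 2, at an estimated 30000 nM, with a likely range from 8000 nM to 100000 nM. That estimate for compound 3 means an expected step of a number no higher from compound 2 to compound 3 (the limit leaves the size open), within the scatter, and a fair chance that the assay again reports only a limit.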

Compound 3, half-maximal inhibitory concentration: 5000 nM
The estimate for compound 3 lay 6.0-fold (0.78 log units) above the measured number; measured number outside the range, below it.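

Read in this assay, the change from chloro to methyl on this aromatic carbon is an at least 6.0-fold lower number from compound 2 to compound 3 (0.77 log units; beyond the scatter), and its true size stays unknown, as compound 2 is held at a limit of the assay: the limit of > 30000 nM in this assay, at which 1 of the 3 values shown sits.

Methyl in place of cyano gives a 1.3-fold higher number from compound 1 to compound 3 (0.12 log units; within the scatter), so the nitrile and the methyl group cannot be told apart at this position. Of the three groups shown, chloro alone stands apart from the other two, which means that the cyano group can be replaced here without a clear change, at least by methyl.

On these data alone, what sets chloro apart from the other two groups stays open. So does whether an amine, a methoxy group or a longer chain such as ethyl on the same aromatic carbon would read like methyl and the nitrile or like chloro.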